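Adding Chlorine to Compound 2: An Expected Shift in Cytotoxicity

The source may hold more compounds than are shown below. What is called first, only, known or untested is meant among the compounds shown, and "the series" means these compounds.

Among the measured compounds shown here, compound 2 `COc1cc([C@@H]2C[C@]2(CO)C(=O)Nc2ccccc2)cc(OC)c1OC` is one of two compounds measured in a functional assay on QGY cells (Homo sapiens) for cytotoxicity, read by MTT assay, with a stated time of 48 h; a higher number here means a weaker inhibitor, a lower number a stronger inhibitor; in this assay compound 2 gives 51300 nM, the higher of the two numbers. The other, compound 1 `COc1cc([C@@H]2C[C@@]2(CO)C(=O)Nc2ccccc2Cl)cc(OC)c1OC`, gives 24500 nM in this assay, a gap that lies beyond the usual scatter. Compound 3 `COc1cc([C@@H]2C[C@]2(CO)C(=O)Nc2ccccc2Cl)cc(OC)c1OC` arises from compound 2 by a single change: chloro in place of hydrogen on an aromatic carbon. For the measured compounds named here, no measured pair shows this change directly, so its size is unknown. A modest step toward stronger inhibition is expected, a 2.0-fold lower number from compound 2 to compound 3 (0.30 log units; within the scatter), because compound 1, which also bears a chloro group, gives 24500 nM. For compound 3 the estimated value is 26000 nM, expected to fall between 10000 nM and 65000 nM.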

Compound 3, half-maximal inhibitory concentration: 15700 nM
Beside the measured number, compound 3's estimate is 1.7-fold (0.22 log units) above it; low and high end bracket the measured number.
By their numbers in this assay, from the lowest: compounds 3 and 1 (each within the scatter of the next); then compound 2.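

In this assay, among the compounds shown here, chloro in place of hydrogen on an aromatic carbon, ortho to a large group, gives a 3.3-fold lower number from compound 2 to compound 3 (0.51 log units; beyond the scatter), the first direct reading of this change. The comparison of the two chloro compounds gives a 1.6-fold lower number from compound 1 to compound 3 (0.19 log units; within the scatter), so the drawn configuration at that saturated ring carbon does not separate them here. That comparison isolates a single difference: the fact that compounds 1 and 3 differ only in the configuration as drawn.

Going by these compounds, what an amine or a bromo group would give in place of this chloro stays open. On these data alone, whether chloro gives a step of like size in the configuration of compound 1 also stays open.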